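Hydroxy for Fluoro on the Aryl Ketone of Compound 1

A few compounds are considered here, and "the series" means these few. Any claim that something is new, unique, unknown or untested is made for them only; others in the source may bear on it.

Going by the values given here, compound 1 `COc1cc(-c2nnc3n2NC(c2ccco2)C(C(=O)c2ccc(F)cc2)S3)cc(OC)c1OC` gives 53700 nM in a functional assay on A549 cells (Homo sapiens) for cytotoxicity, read by MTT assay, with a stated time of 48 h (on this read-out lower numbers stand for stronger inhibition and higher numbers for weaker inhibition), the highest of the two numbers measured so far; compound 2 `COc1cc(-c2nnc3n2NC(c2cccs2)C(C(=O)c2ccc(F)cc2)S3)cc(OC)c1OC` gives 45000 nM, and the step of a 1.2-fold lower number from compound 1 to compound 2 (0.08 log units; within the scatter) stays within the scatter. Compound 3 `COc1cc(-c2nnc3n2NC(c2ccco2)C(C(=O)c2ccc(O)cc2)S3)cc(OC)c1OC` carries hydroxy in place of fluoro on an aromatic carbon. Among the compounds with values here, no measured step touches this position: the only step seen, a 1.2-fold lower number from compound 1 to compound 2 (0.08 log units; within the scatter), concerns the saturated ring carbon and gives no guide, so no shift beyond the scatter is expected in this assay. Compound 3 is therefore estimated at 50000 nM, with a range of 15000 nM to 160000 nM, a step of a 1.1-fold lower number from compound 1 to compound 3 (0.03 log units; within the scatter) that is expected to remain within the scatter.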

Compound 3, half-maximal inhibitory concentration: 93400 nM
For compound 3 the middle estimate is 1.9-fold (0.27 log units) below the measured one, within the range that was stated.
By their numbers in this assay, from the lowest: compounds 2, 1 and 3 (each within the scatter of the next, the first and the last beyond it).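

In this assay, going by these compounds alone, hydroxy in place of fluoro on the aromatic carbon gives a 1.7-fold higher number from compound 1 to compound 3 (0.24 log units; within the scatter) and so adds the first reading at this position. Within the data shown here, this exchange on the aryl ketone, para to a large group, stays within the scatter, and the series so far shows no shift beyond the scatter at this site. Nothing available explains this result.

Open, going by these compounds, is whether an amine or a carboxylic acid on this aromatic carbon would move the number beyond the scatter. Also open, on these data alone, is whether hydroxy for fluoro reads the same with the thiophen-2-yl group of compound 2.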